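Extending the chain on the core: from compound 2 to compound 4

The source may hold more compounds than are shown below. What is called first, only, known or untested is meant among the compounds shown, and "the series" means these compounds.

Measured so far:
Compound 1 `Cc1nn(C)c2c1C(c1ccccc1)=NCC(=O)N2`: 16 mg/kg
Compound 2 `Cc1nn(C)c2c1C(c1ccccc1Cl)=NCC(=O)N2`: 16 mg/kg
Compound 3 `CCc1nn(C)c2c1C(c1cccc(F)c1)=NCC(=O)N2`: 32 mg/kg

In a functional assay on the whole organism with Rattus norvegicus as the target (on this read-out higher numbers stand for an effect only at larger amounts of compound and lower numbers for an effect already at smaller amounts), compound 2 gives 16 mg/kg and stands level with compound 1, which gives 16 mg/kg. Compound 3, with its ethyl and its fluoro, gives 32 mg/kg in this assay, a number that lies within the scatter of both others, so the three measured compounds are not separated on this read-out. Going by the values given here, the only single step measured, no change at the digits printed from compound 1 to compound 2 (within the scatter), shows no change within the scatter.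

Compound 4 `CCCc1nn(C)c2c1C(c1ccccc1Cl)=NCC(=O)N2` differs from compound 2 by ethyl in place of hydrogen on a saturated chain carbon bound to an aromatic carbon. Among the compounds with values here, no measured step bears directly on this change; the closest hint is compound 3, whose ethyl gives a number within the scatter of compound 2. The expected step of a 1.3-fold higher number from compound 2 to compound 4 (0.10 log units; within the scatter) is therefore none beyond the scatter, perhaps leaning toward a slightly higher number. Compound 4 is estimated at 20 mg/kg in this assay, with a range from 8 mg/kg to 64 mg/kg.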

Compound 4, minimum effective dose: 250 mg/kg
Estimate against measurement, compound 4: 13-fold (1.10 log units) below; the measured number lies above the stated range.
By their numbers in this assay, from the lowest: compounds 1, 2 and 3 (each within the scatter of the next); then compound 4.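

Ethyl in place of hydrogen on a saturated chain carbon bound to an aromatic carbon, the same difference as methyl to propyl, brings a 16-fold higher number from compound 2 to compound 4 (1.19 log units; beyond the scatter) in this assay. Among the compounds shown, this is the first single change to lie beyond the scatter, so this place on the core matters to the read-out in a way the step from hydrogen to chloro on the aromatic carbon did not reveal. Nothing available here accounts for the size of this rise.

The compounds shown leave open whether the number climbs gradually with chain length or jumps at one particular length, and whether the same change would have a similar effect on compound 1, which lacks the chloro. They also leave open how a butyl chain, an isopropyl group or an amine at this place would read.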